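Indole sulfone carboxamides: from pyrrolidine amide to acyl sulfonamide

The source may report more compounds than this note shows. Statements on the series, on what has been measured and on what is new or still open speak of the compounds shown alone.

Compound 1 `Cc1cc(C)cc(S(=O)(=O)c2c(C(=O)N[C@@H]3CCN(Cc4cccnc4)C3)[nH]c3ccc(Cl)cc23)c1` is the reference for this step. In an ADME assay on MT4 cells (Homo sapiens) for cytotoxicity, read by MTT assay, with a stated time of 5 days (a higher number here means that more compound is tolerated, a lower number that less compound is tolerated), compound 1 gives 36500 nM, the higher of the two numbers recorded so far. Compound 2 `Cc1cc(C)cc(S(=O)(=O)c2c(C(=O)N[C@H]3CCN(Cc4cccnc4)C3)[nH]c3ccc(Cl)cc23)c1`, which in this assay gives 22800 nM, is its nearest neighbour, and the step of a 1.6-fold lower number from compound 1 to compound 2 (0.20 log units; within the scatter) lies within the scatter, as expected because of the fact that compounds 1 and 2 differ only in the configuration as drawn.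

Compound 3 `Cc1cc(C)cc(S(=O)(=O)c2c(C(=O)NS(=O)(=O)c3ccccc3)[nH]c3ccc(Cl)cc23)c1` is not yet measured. It differs from compound 1 as follows: phenylsulfonyl in place of 1-((pyridin-3-yl)methyl)pyrrolidin-3-yl on an amide-type nitrogen. For the measured compounds named here, the only measured step concerns configuration alone and does not bear on the exchange of the amide substituent, so no direction can be read from the data. The working expectation is therefore a step of a 1.2-fold lower number from compound 1 to compound 3 (0.09 log units; within the scatter) that stays within the scatter, with a wide margin to either side. Compound 3 is estimated at 30000 nM in this assay, with a range from 8000 nM to 100000 nM.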

Compound 3, half-maximal cytotoxic concentration: 167000 nM
Compound 3: middle estimate off by 5.6-fold (0.75 log units), on the low side; the whole stated range lies below it.
By their numbers in this assay, from the lowest: compounds 2 and 1 (each within the scatter of the next); then compound 3.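

At the amide-type nitrogen, the substituent matters in this assay: phenylsulfonyl in place of 1-((pyridin-3-yl)methyl)pyrrolidin-3-yl gives a 4.6-fold higher number from compound 1 to compound 3 (0.66 log units; beyond the scatter) and a 7.3-fold higher number from compound 2 to compound 3 (0.86 log units; beyond the scatter). Both steps run the same way and lie beyond the scatter, so the exchange shows up against either drawn configuration of the group that leaves, whereas the earlier pair gave only a step within the scatter. What is known about these compounds offers no reason for the rise and does not assign it to any one part of either group.

Still open, going by these compounds, is whether the higher number follows the sulfonyl link or the phenyl ring: a benzoyl or a methylsulfonyl group on the same nitrogen would separate the two. Also open, on these data alone, is where a plain benzyl group at that nitrogen would stand.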